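This account rests on a few compounds, and the source may have more. Where it says the series, first, only, none or still open, it means among the compounds named here.

Compound 1 `Nc1scc(CN2CCN(c3cc(Cl)cc(Cl)c3)CC2)c1C(=O)c1ccc(Cl)cc1`: -22%
Compound 2 `Nc1scc(CN2CCN(c3ccc(Cl)cc3F)CC2)c1C(=O)c1ccc(Cl)cc1`: -9.4%
Compound 3 `Nc1scc(CN2CCN(c3c(F)cccc3F)CC2)c1C(=O)c1ccc(Cl)cc1`: -23%

In a functional assay on CHO cells with adenosine receptor A1 (Homo sapiens) as the target, read by cAMP accumulation and immunoassay, with a stated time of 6 min, tested at 0.1 uM (on this read-out lower numbers stand for a stronger effect and higher numbers for a weaker effect at the one concentration tested), compound 3 gives the lowest of the three numbers, though its gap to compound 1 is small, a number 1 percentage points lower from compound 1 to compound 3 (within the scatter), while compound 2 sits clearly apart, a number 13.6 percentage points lower from compound 2 to compound 3 (beyond the scatter). Compound 4 `Nc1scc(CN2CCN(c3cccc(Cl)c3)CC2)c1C(=O)c1ccc(Cl)cc1` differs from compound 3 only at the group on the ring nitrogen: 3-chlorophenyl in place of 2,6-difluorophenyl on an amine nitrogen in a ring. All three measured steps swap that same aryl group; two of them (a number 12.6 percentage points higher from compound 1 to compound 2 (beyond the scatter) and a number 13.6 percentage points lower from compound 2 to compound 3 (beyond the scatter)) moved the number beyond the scatter, one did not. Since compound 1 carries a chlorinated phenyl at the same place and gives -22%, compound 4 is expected to land near compound 3, with a step of about a number 6 percentage points higher from compound 3 to compound 4 (within the scatter). The estimate for compound 4 is -17%, within -31% to -3%.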

Compound 4, a percentage reported as activity, at one concentration (the size of the read-out at that concentration, not a potency): -20%
Beside the measured number, compound 4's estimate is 3 percentage points above it; measured number inside the range.
By their numbers in this assay, from the lowest: compounds 3, 1 and 4 (each within the scatter of the next); then compound 2.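

Taking away one chloro from the 3,5-dichlorophenyl group changes nothing that this read-out can separate, a number 2 percentage points higher from compound 1 to compound 4 (within the scatter), and 3-chlorophenyl likewise stays level with 2,6-difluorophenyl, a number 3 percentage points higher from compound 3 to compound 4 (within the scatter). In this assay, 4-chloro-2-fluorophenyl remains the exception among these aryl groups, with a number 10.6 percentage points lower from compound 2 to compound 4 (beyond the scatter). Nothing available here explains why that one group stands apart.

Going by these compounds, whether that difference follows the chloro of the 4-chloro-2-fluorophenyl group or its fluoro stays open, and 4-chlorophenyl and 2-fluorophenyl would separate the two. A benzyl group on the same amine nitrogen in a ring also remains untested among the compounds shown.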